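This account rests on a few compounds, and the source may have more. Where it says the series, first, only, none or still open, it means among the compounds named here.

Working notes on the series. The three measured compounds share one core and differ only in the group on a carbon with a double bond to nitrogen. In a functional assay on A549 cells (Homo sapiens) for cytotoxicity, read by MTT assay, with a stated time of 72 h (a higher number here means a weaker inhibitor, a lower number a stronger inhibitor), compound 1 `CN(C)CCn1cnnc1-c1cc(Oc2ccc(NC(=O)N/N=C/c3ccc(F)cc3Cl)cc2F)ccn1` gives 1120 nM. Compound 2 `CN(C)CCn1cnnc1-c1cc(Oc2ccc(NC(=O)N/N=C/c3c(O)ccc4ccccc34)cc2F)ccn1` gives 880 nM in this assay, and compound 3 `CN(C)CCn1cnnc1-c1cc(Oc2ccc(NC(=O)N/N=C/c3c[nH]c4ccccc34)cc2F)ccn1` gives 820 nM in this assay. Compound 3 shows the lowest of the three numbers, yet its steps to the other two lie within the scatter: a 1.4-fold lower number from compound 1 to compound 3 (0.14 log units; within the scatter) and a 1.1-fold lower number from compound 2 to compound 3 (0.03 log units; within the scatter). The remaining step, a 1.3-fold lower number from compound 1 to compound 2 (0.10 log units; within the scatter), is likewise within the scatter.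

Compound 4 `COc1cc(/C=N/NC(=O)Nc2ccc(Oc3ccnc(-c4nncn4CCN(C)C)c3)c(F)c2)cc(OC)c1OC` has not been measured in this assay. It differs from compound 3 in one place: 3,4,5-trimethoxyphenyl in place of 1H-indol-3-yl on a carbon with a double bond to nitrogen. All three measured steps exchange the group on this same carbon, and none moved the number beyond the scatter, so no step beyond the scatter is expected for a 1.1-fold higher number from compound 3 to compound 4 (0.04 log units; within the scatter). The 3,4,5-trimethoxyphenyl group is unlike any of the three groups already tested, which makes the range wider. Compound 4 is estimated at 900 nM in this assay, expected to fall between 400 nM and 2200 nM.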

Compound 4, half-maximal inhibitory concentration: > 100000 nM
Compound 4 gave a limit, no number; the forecaster's own chance of this, stated with the estimate: 5%; middle value at least 110-fold (2.04 log units) away from the limit.
By their numbers in this assay, from the lowest: compounds 3, 2 and 1 (each within the scatter of the next). At a limit, above all of these: compound 4.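

The group on a carbon with a double bond to nitrogen is not interchangeable in this assay: exchanges among the three earlier groups stayed within the scatter, whereas 3,4,5-trimethoxyphenyl gives an at least 120-fold higher number from compound 3 to compound 4 (2.08 log units; beyond the scatter), an at least 110-fold higher number from compound 2 to compound 4 (2.05 log units; beyond the scatter) and an at least 89-fold higher number from compound 1 to compound 4 (1.95 log units; beyond the scatter). The entry for compound 4 is a limit and not a number, so each of these steps has only a lower bound: the limit of > 100000 nM in this assay, at which 1 of the 4 values shown sits. Going by these compounds alone, this place therefore accepts 2-chloro-4-fluorophenyl, 2-hydroxynaphthalen-1-yl and 1H-indol-3-yl with no separation among them, while the sharp break appears only with the one group of the four that bears methoxy groups.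

The compounds shown leave open whether the break needs all three methoxy groups or follows from any one of them. A plain phenyl group, or a phenyl group carrying a single methoxy group, on this carbon would bear on that question.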